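Thiourea sulfonamides: nitrophenyl placement and cytotoxicity

The source may report more compounds than this note shows. Statements on the series, on what has been measured and on what is new or still open speak of the compounds shown alone.

Working notes on the cytotoxicity read-out for this small set. In an ADME assay on HEK-293T cells (Homo sapiens) for cytotoxicity, read by CCK-8 assay, with a stated time of 48 h (on this read-out lower numbers stand for stronger inhibition and higher numbers for weaker inhibition), compound 1 `O=S(=O)(NCCNC(=S)Nc1cc(C(F)(F)F)cc(C(F)(F)F)c1)c1ccc(-c2ccccc2OCc2ccccc2)s1` gives 8500 nM. Compound 2 `Cc1ccc(-c2ccsc2S(=O)(=O)NCCNC(=S)Nc2ccc([N+](=O)[O-])cc2)c(Oc2ccc(O)c(O)c2)c1` gives 8200 nM in this assay. Compound 3 `COc1cccc(NC(=O)NCCNS(=O)(=O)c2ccc(-c3ccccc3OCc3ccccc3)s2)c1` is different: its result in this assay is a limit of the assay, > 20000 nM, not a number, as noted in the limit of > 20000 nM in this assay, at which 1 of the 3 values shown sits. Among the two numbers in hand, compound 2 and compound 1 sit within the scatter of each other, so no order can be read between them; compound 2 is simply one of the two numbered results.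

Compound 4 `Cc1ccc(-c2ccsc2S(=O)(=O)NCCNC(=S)Nc2cccc([N+](=O)[O-])c2)c(Oc2ccc(O)c(O)c2)c1` has not yet been measured in this assay. It differs from compound 2 in one place: 3-nitrophenyl in place of 4-nitrophenyl on an amide-type nitrogen. The two hold the same atoms, joined differently, and the change stays within the same ring on the amide-type nitrogen bound to the thiocarbonyl carbon.

Among the compounds with values here, no measured pair in this set isolates such a change, so there is no step to lean on. The expectation is that the step of a 1.0-fold higher number from compound 2 to compound 4 (0.02 log units; within the scatter) will be small, no more than the usual scatter, in either direction. Compound 4 is accordingly expected to give about 8500 nM in this assay, with a range from 4000 nM to 18000 nM.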

Compound 4, half-maximal inhibitory concentration: 7900 nM
Beside the measured number, compound 4's estimate is 1.1-fold (0.03 log units) above it; the range from low to high includes it.
By their numbers in this assay, from the lowest: compounds 4, 2 and 1 (each within the scatter of the next). At a limit, above all of these: compound 3.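

In this assay, 3-nitrophenyl in place of 4-nitrophenyl on the amide-type nitrogen bound to the thiocarbonyl carbon gives a 1.0-fold lower number from compound 2 to compound 4 (0.02 log units; within the scatter), so this exchange of isomers leaves no readable change in the cytotoxicity read-out. Within the data shown here, this is the first pair that differs in one place only; compound 1 and compound 3 each differ from the others in more than one place and could say nothing about the placement of the nitro group on this ring. The pair shows only that these two placements cannot be told apart on this read-out, and nothing in hand gives a cause for that.

Compound 3 stands at a limit of the assay, > 20000 nM, and as it differs from the others in more than one place, it cannot be read against them for any single feature. Open, from the compounds shown here alone, is whether this position stays as flat with a different group on the ring, such as an amine or a carboxylic acid in place of the nitro group, or with an unsubstituted phenyl on the same nitrogen.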